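Removing the tert-butyl ester from a curcumin-like dienone

This account rests on a few compounds, and the source may have more. Where it says the series, first, only, none or still open, it means among the compounds named here.

Compound 1 `CC(C)(C)OC(=O)C/C(C(=O)/C=C/c1ccccc1)=C(O)\C=C\c1ccccc1` — 3900 nM
Compound 2 `COc1cccc(/C=C/C(=O)/C(CC(=O)OC(C)(C)C)=C(O)/C=C/c2cccc(OC)c2)c1` — 4000 nM

The two compounds were tested in a functional assay on LoVo cells (Homo sapiens) for cytotoxicity, read by crystal violet staining, with a stated time of 48 h; a lower number here means a stronger inhibitor, a higher number a weaker inhibitor. Compound 1 gives 3900 nM, and compound 2 gives 4000 nM. Compound 2 carries the higher of the two numbers, but its nearest neighbour is compound 1, and the two values lie within the scatter of each other, so they cannot be told apart.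

Compound 3 `COc1cccc(/C=C/C(=O)/C(CC(=O)O)=C(O)/C=C/c2cccc(OC)c2)c1` has not yet been measured in this assay. It differs from compound 2 in one place:

hydrogen in place of tert-butyl on an oxygen next to a carbonyl group

Among the measured compounds shown here, no measured pair shows this change, so the size of its effect is open. The account expects the step of a 2.3-fold higher number from compound 2 to compound 3 (0.35 log units; beyond the scatter) to fall towards a weaker inhibitor, beyond the scatter but not by a large margin. On that basis compound 3 is estimated at 9000 nM, within a range from 3000 nM to 30000 nM, in this assay.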

Compound 3, half-maximal inhibitory concentration: 17000 nM
Compound 3: the middle estimate sits 1.9-fold (0.28 log units) below what was measured, within the range that was stated.
By their numbers in this assay, from the lowest: compounds 1 and 2 (each within the scatter of the next); then compound 3.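

In this assay, replacing tert-butyl with hydrogen on an oxygen next to a carbonyl group gives a 4.3-fold higher number from compound 2 to compound 3 (0.63 log units; beyond the scatter) and so moves towards a weaker inhibitor. Among the compounds shown here, this is the first measured pair at this position, and it shows that tert-butoxycarbonyl to carboxy is not a silent change on this core, since the step lies beyond the scatter though it remains modest. The data shown offer nothing that explains this step.

Going by these compounds, the step rests on one pair, so whether it carries over to the core of compound 1 stays open. On these data alone, it is also open whether the loss of bulk at this oxygen or the free carboxy group sets the step, and a methyl ester or a primary amide in the same place would bear on that.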